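Adding a methoxy group to a fluorinated analogue

A few compounds are considered here, and "the series" means these few. Any claim that something is new, unique, unknown or untested is made for them only; others in the source may bear on it.

Of the compounds shown here, three have been measured in a functional assay on HeLa cells (Homo sapiens) for antiproliferative activity, read by sulforhodamine B assay, with a stated time of 48 h; on this read-out higher numbers stand for weaker inhibition of growth and lower numbers for stronger inhibition of growth. Compound 1 `COc1ccc(Cn2cc(CNC(=O)c3cn(-c4ccccc4)nc3-c3ccccc3)nn2)cc1` gives 6900 nM. Compound 2 `COc1ccc(Cn2cc(CNC(=O)c3cn(-c4ccccc4)nc3-c3ccccc3)nn2)cc1OC` gives 10800 nM, and compound 3 `COc1ccc(Cn2cc(CNC(=O)c3cn(-c4ccccc4)nc3-c3ccc(F)cc3)nn2)cc1` gives 870 nM, the lowest number of the three.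

The difference between compound 1 and compound 2 is this: methoxy in place of hydrogen on an aromatic carbon That change made a 1.6-fold higher number from compound 1 to compound 2 (0.19 log units; within the scatter). The difference between compound 1 and compound 3 is this: fluoro in place of hydrogen on an aromatic carbon That change made a 7.9-fold lower number from compound 1 to compound 3 (0.90 log units; beyond the scatter).

Compound 4 `COc1ccc(Cn2cc(CNC(=O)c3cn(-c4ccccc4)nc3-c3ccc(F)cc3)nn2)cc1OC` has not yet been measured. For the measured compounds named here, it differs from compound 3 in this way: methoxy in place of hydrogen on an aromatic carbon This is the same change as the one from compound 1 to compound 2, at the same place on the same kind of ring, while the two cores differ as described for compound 1 and compound 3.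

Because the earlier step was a 1.6-fold higher number from compound 1 to compound 2 (0.19 log units; within the scatter), a step of similar size is expected here, estimated as a 1.5-fold higher number from compound 3 to compound 4 (0.17 log units; within the scatter). Compound 4 is therefore expected to give about 1300 nM in this assay, most likely somewhere between 500 nM and 3500 nM.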

Compound 4, concentration for 50% growth inhibition: 200 nM
Compound 4: middle estimate off by 6.5-fold (0.81 log units), on the high side; measured number outside the range, below it.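

In this assay, the methoxy that turns 4-methoxybenzyl into 3,4-dimethoxybenzyl gave a 4.4-fold lower number from compound 3 to compound 4 (0.64 log units; beyond the scatter), so a change that stayed within the scatter on the core of compound 1 does not behave the same way on the fluorinated core: the same change on two cores in this assay, a 1.6-fold higher number (0.19 log units; within the scatter) from compound 1 to compound 2 and a 4.4-fold lower number (0.64 log units; beyond the scatter) from compound 3 to compound 4, 6.8-fold (0.83 log units) apart, beyond the scatter of two such steps. Seen from the other side, the fluoro change gave a 54-fold lower number from compound 2 to compound 4 (1.73 log units; beyond the scatter), and its size depends on whether the added methoxy is present: the same change on two cores in this assay, a 7.9-fold lower number (0.90 log units; beyond the scatter) from compound 1 to compound 3 and a 54-fold lower number (1.73 log units; beyond the scatter) from compound 2 to compound 4, 6.8-fold (0.83 log units) apart, beyond the scatter of two such steps. These two comparisons rest on the same four compounds and are therefore one finding, which shows that the step from one core cannot simply be carried over to the other here, but does not show why or whether the same holds on any other core.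

The compounds shown leave open whether a chloro group in place of the fluoro would give the same result. They also leave open whether an ethoxy or a hydroxy group in place of the added methoxy would do so.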